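Changing the group on a carbonyl carbon

The source may report more compounds than this note shows. Statements on the series, on what has been measured and on what is new or still open speak of the compounds shown alone.

Values so far in a functional assay on B16-F10 cells (Mus musculus) for antiproliferative activity, read by MTT assay, with a stated time of 48 h (a higher number here means a weaker inhibitor, a lower number a stronger inhibitor), are these
- compound 1 `COc1ccc(/C=C/c2cc(OC)cc(OC)c2/C=C/C(=O)c2cccc(Cl)c2)cc1` gives 3.3 ug/mL
- compound 2 `CCOc1ccc(C(=O)/C=C/c2c(/C=C/c3ccc(OC)cc3)cc(OC)cc2OC)cc1` gives 6.4 ug/mL

Compound 2 at 6.4 ug/mL sits within the scatter of compound 1, so these two numbers cannot be ranked. Compound 3 `COc1ccc(/C=C/c2cc(OC)cc(OC)c2/C=C/C(=O)c2ccccc2C)cc1` keeps the shared core and differs from compound 2 in one place, with 2-methylphenyl in place of 4-ethoxyphenyl on a carbonyl carbon.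

Within the data shown here, the only measured step that bears on this also swaps the group on a carbonyl carbon, putting 4-ethoxyphenyl in place of 3-chlorophenyl. It reads a 1.9-fold higher number from compound 1 to compound 2 (0.29 log units; within the scatter) and so stays within the scatter. Among the measured compounds shown here, one step is thin evidence, and no compound with 2-methylphenyl has been measured yet. Starting from compound 2 at 6.4 ug/mL and that small step, no change beyond the scatter is expected in this assay here. The estimated step is a 1.4-fold lower number from compound 2 to compound 3 (0.15 log units; within the scatter) and no more than that is expected. For compound 3 the expected value is 4.5 ug/mL with an estimated range from 2 ug/mL to 9.5 ug/mL for this measurement.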

Compound 3, half-maximal inhibitory concentration: 6.1 ug/mL
For compound 3 the middle estimate is 1.4-fold (0.13 log units) below the measured one; measured number inside the range.
By their numbers in this assay, from the lowest: compounds 1, 3 and 2 (each within the scatter of the next).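

In this assay the group on this carbonyl carbon now comes in three forms, and both new swaps, 2-methylphenyl in place of 4-ethoxyphenyl (a 1.0-fold lower number from compound 2 to compound 3 (0.02 log units; within the scatter)) and 2-methylphenyl in place of 3-chlorophenyl (a 1.8-fold higher number from compound 1 to compound 3 (0.27 log units; within the scatter)), stay within the scatter. The three groups therefore cannot be ranked, even though one carries chlorine, one carries oxygen and 2-methylphenyl carries only carbon, and even though going from 4-ethoxyphenyl to 2-methylphenyl takes the group from 9 heavy atoms to 7 and removes its hydrogen-bond acceptor. No measurement of any property of these groups stands beside these numbers, so they come with no explanation.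

All three groups shown are substituted phenyl rings, so it remains open whether a phenyl ring bearing an amine or a carboxylic acid, or a plain alkyl chain with no ring at all, would move the number beyond the scatter. From the compounds shown here alone, whether these three groups also stay this close on other cell types remains open too.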